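The compounds below may be only part of what the source reports. "The series", "measured", "known", "first", "only" and "open" are said of these compounds alone.

Measured in an ADME assay on KB cells (Homo sapiens) for cytotoxicity, read by MTT assay, with a stated time of 72 h; a lower number here means that less compound is tolerated, a higher number that more compound is tolerated:
compound 1 `Clc1ccc(Nc2nc(-c3ccccn3)cs2)nc1`: 98600 nM
compound 2 `Clc1ccc(Nc2nc(-c3ccccn3)c(Cl)s2)nc1`: 326000 nM
compound 3 `COc1ccc(-c2nc(Nc3ccc(Cl)cn3)sc2Cl)nc1`: 248000 nM

Compound 2 shares the upper end of these numbers with compound 3, and only compound 1 stands clearly apart. Among the compounds with values here, the one step beyond the scatter is modest: a 3.3-fold higher number from compound 1 to compound 2 (0.52 log units; beyond the scatter), with chloro in place of hydrogen on an aromatic carbon. The other step gives no separation: a 1.3-fold lower number from compound 2 to compound 3 (0.12 log units; within the scatter), with methoxy in place of hydrogen on an aromatic carbon.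

The next comparison is compound 4 `Clc1ccc(Nc2nc(-c3cnccn3)c(Cl)s2)nc1`, which differs from compound 2 as follows: pyrazin-2-yl in place of pyridin-2-yl on an aromatic carbon. In words, this is pyrazin-2-yl in place of pyridin-2-yl on an aromatic carbon, next to the ring nitrogen of the five-membered aromatic ring.

Within the data shown here, neither measured step exchanges one aromatic ring for another, so the data hold no direct precedent. The closest guide is the methoxy step, a 1.3-fold lower number from compound 2 to compound 3 (0.12 log units; within the scatter), and the chloro step shows that changes in this series have so far remained modest. No shift beyond the scatter is therefore expected in this assay. The expected step is small: a 1.3-fold lower number from compound 2 to compound 4 (0.10 log units; within the scatter). Compound 4 is estimated at 260000 nM, with an expected range of 110000 nM to 550000 nM.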

Compound 4, half-maximal cytotoxic concentration in the KB assay: 3170 nM
The estimate for compound 4 lay 82-fold (1.91 log units) above the measured number; measured number outside the range, below it.
By their numbers in the KB assay, from the lowest: compound 4; then compound 1; then compounds 3 and 2 (each within the scatter of the next).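

Within the data shown here, in the KB assay this position proves highly sensitive to the ring it carries: pyrazin-2-yl in place of pyridin-2-yl gives a 100-fold lower number from compound 2 to compound 4 (2.01 log units; beyond the scatter) and so sets the largest step so far. Both groups hold 6 heavy atoms and differ by one ring carbon exchanged for a nitrogen, yet the earlier changes gave only a 3.3-fold higher number from compound 1 to compound 2 (0.52 log units; beyond the scatter) for chloro and a 1.3-fold lower number from compound 2 to compound 3 (0.12 log units; within the scatter) for methoxy, so a small exchange in this ring can outweigh both. In a physicochemical assay for solubility, in phosphate buffer, with a stated time of 2 h, at pH 7.4 (a higher number here means a more soluble compound, a lower number a less soluble compound), the step for this change cannot be read. In the physicochemical assay compound 2 gives < 10000 nM, which is a limit of the assay and not a number. In the physicochemical assay compound 4 gives < 10000 nM, which is also a limit of the assay and not a number. Both compounds sit at a limit of the assay rather than at a number: the limit of < 10000 nM in the physicochemical assay, at which 2 of the 2 values shown sit.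

From the compounds shown here alone, whether phenyl, with no ring nitrogen, or pyrimidin-2-yl at this place would stand nearer to compound 2 or to compound 4 remains open, and one exchange cannot separate the count of ring nitrogens from where the added nitrogen sits. Also open, going by these compounds, is whether a methoxy group or an amine on the pyrazin-2-yl ring would shift the number of compound 4, as the methoxy group on the pyridin-2-yl ring of compound 2 did not.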